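A few compounds are considered here, and "the series" means these few. Any claim that something is new, unique, unknown or untested is made for them only; others in the source may bear on it.

In a functional assay on HCT-116 cells (Homo sapiens) for inhibition, read by MTT assay, with a stated time of 72 h, in the presence of a further agent that is not named here (a higher number here means that more compound is needed for the effect, a lower number that less compound is needed), compound 1 `O=C(Nc1cc(Cl)cc(Cl)c1)Nc1cc(Cl)nc(Cl)c1` gives 11400 nM and compound 2 `O=C(Nc1ccnc(Cl)c1)Nc1cc(Cl)nc(Cl)c1` gives 16100 nM. These two values lie within the scatter of each other, so compound 2 stands level with compound 1 on the numbers available, and neither can be ranked ahead of the other. Compound 3 `CC(C)Oc1cc(NC(=O)Nc2cc(Cl)nc(Cl)c2)cc(Cl)n1` follows from compound 2 through a single change, isopropoxy in place of hydrogen on an aromatic carbon, next to the ring nitrogen and meta to a chloro group. Going by the values given here, no measured pair shows what this change does in this assay, so any forecast rests on little evidence. Among the compounds with values here, the only guide is the level set by compound 1 at 11400 nM and compound 2 at 16100 nM, and a result near that level is the natural expectation. A modest move towards a lower number is expected, with an estimated 2.0-fold lower number from compound 2 to compound 3 (0.30 log units; within the scatter), though a result within the scatter would be no surprise. Compound 3 is estimated at 8000 nM, with an expected range from 2500 nM to 25000 nM.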

Compound 3, half-maximal effective concentration: 5230 nM
Compound 3: middle estimate off by 1.5-fold (0.18 log units), on the high side; the range from low to high includes it.
By their numbers in this assay, from the lowest: compound 3; then compounds 1 and 2 (each within the scatter of the next).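

In this assay the hydrogen on this aromatic carbon, next to the ring nitrogen and meta to a chloro group, proves open to replacement: isopropoxy there gives a 3.1-fold lower number from compound 2 to compound 3 (0.49 log units; beyond the scatter) and so moves the number beyond the scatter, towards less compound being needed. Going by these compounds alone, compounds 1 and 2 could not show this, since their values lie within the scatter of each other and no single-change step joins them, so this is the only change that can be read on its own. Nothing measured here accounts for the effect of isopropoxy at this position.

With a single substituent at this carbon, the compounds shown leave open whether the step depends on isopropoxy itself, or whether methoxy, a longer chain such as butoxy, or an amine such as dimethylamino would give a similar number or a different one. They also leave open whether the chloro group on the same ring is needed for the step, and whether the step would carry over to the core of compound 1.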